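Two Chlorines on the Core, One Set to Change

A few compounds are considered here, and "the series" means these few. Any claim that something is new, unique, unknown or untested is made for them only; others in the source may bear on it.

Compound 1 `ClCc1ccccc1Cn1cnc2c(Cl)nc(Cl)nc21` was tested in a functional assay on SK-MEL-28 cells (Homo sapiens) for cytotoxicity, read by sulforhodamine B assay, with a stated time of 48 h (a lower number here means a stronger inhibitor of growth, a higher number a weaker inhibitor of growth), and gives 1230 nM. Compound 2 `ClCc1ccccc1Cn1cnc2ncnc(Cl)c21`, which shares the same benzyl arm, gives 4460 nM in this assay, so compound 1 has the lower of the two numbers, and the gap between them lies beyond the usual scatter. Compound 3 `Nc1nc(Cl)c2ncn(Cc3ccccc3CCl)c2n1` has not yet been measured in this assay. It differs from compound 1 in one place: amino in place of chloro on an aromatic carbon. Among the measured compounds shown here, no measured pair shows what this exchange does, so the expectation can only lean on the two numbers above. The step expected in this assay is a modest weakening, a 2.1-fold higher number from compound 1 to compound 3 (0.33 log units; beyond the scatter), smaller than the gap between compound 1 and compound 2 but still just outside the scatter. Compound 3 is therefore expected to give about 2600 nM, with a plausible range from 900 nM to 7500 nM.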

Compound 3, concentration for 50% growth inhibition: 4790 nM
The estimate for compound 3 lay 1.8-fold (0.27 log units) below the measured number, and the stated range covers the measured number.
By their numbers in this assay, from the lowest: compound 1; then compounds 2 and 3 (each within the scatter of the next).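

The chloro group between two ring nitrogen atoms of compound 1 can give way to amino and growth inhibition remains, though at a cost: this assay records a 3.9-fold higher number from compound 1 to compound 3 (0.59 log units; beyond the scatter) and this modest step lies beyond the scatter. Among the compounds shown here, this is the first measured pair at this position, and with the rest of the structure unchanged, it shows the exchange moving the number in the weaker direction. Nothing measured here explains the step.

Going by these compounds, whether any other group at this carbon would fare better stays open, since a methoxy group, a hydroxyl group or a methylamino group could each give a different number. The compounds shown also leave open whether the same exchange would have a similar effect at the other chloro group of the shared core.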